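Trading a large aryl group for a small ethynyl

A few compounds are considered here, and "the series" means these few. Any claim that something is new, unique, unknown or untested is made for them only; others in the source may bear on it.

Compound 1 `O=C(Nc1cccc(F)c1)c1cc(=O)[nH]c2cc(C3=CCOCC3)ccc12` and compound 2 `O=C(Nc1cccc(F)c1)c1cc(=O)[nH]c2cc(-c3ccc(F)c(CO)c3)ccc12` share a core and differ in one group on an aromatic carbon. In a functional assay on KYSE-70 cells for antiproliferative activity against KYSE-70 cell line (Homo sapiens), read by MTT assay, with a stated time of 72 h (on this read-out lower numbers stand for stronger inhibition and higher numbers for weaker inhibition), compound 1 gives 10500 nM. Compound 2 gives > 20000 nM, which is a limit of the assay and not a number. Going by the values given here, the only measured step is an at least 1.9-fold higher number from compound 1 to compound 2 (0.27 log units; that floor lies within the scatter), so it offers a floor and not a full size.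

Compound 3 `C#Cc1ccc2c(C(=O)Nc3cccc(F)c3)cc(=O)[nH]c2c1` now carries ethynyl in place of 4-fluoro-3-(hydroxymethyl)phenyl on an aromatic carbon. The aromatic group of compound 2 goes, and what enters is smaller even than the ring it replaced in compound 1. Nothing measured yet shows how ethynyl itself behaves, so compound 1 at 10500 nM is the nearest guide. A result in that region would mean a modest move toward stronger inhibition in this assay, though a second reading at the limit remains possible. The expected change is an at least 1.8-fold lower number from compound 2 to compound 3 (0.25 log units; that floor lies within the scatter). The estimated value for compound 3 is 11000 nM, with an expected range from 4000 nM to 25000 nM.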

Compound 3, half-maximal inhibitory concentration: 9500 nM
Estimate against measurement, compound 3: 1.2-fold (0.06 log units) above; low and high end bracket the measured number.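

Going by these compounds alone, replacing the aryl group with ethynyl gives an at least 2.1-fold lower number from compound 2 to compound 3 (0.32 log units; beyond the scatter) in this assay, the first step at this position that lies beyond the scatter. That size is only a floor, as the reading for compound 2 is a limit of the assay and not a number: the limit of > 20000 nM in this assay, at which 1 of the 3 values shown sits.

The other new comparison, a 1.1-fold lower number from compound 1 to compound 3 (0.04 log units; within the scatter), lies within the scatter, so the small ethynyl group, with no ring, and the six-membered non-aromatic ring of compound 1 read alike here, which shows that a ring on this aromatic carbon is not needed for a value in this region.

Open, from the compounds shown here alone, is whether the poor reading of compound 2 belongs to its aromatic ring as such or to the fluorine and hydroxymethyl on that ring, a question that a plain phenyl group at this position could help to settle. Also open, going by these compounds, is whether a different kind of group here, such as an amine, a carboxylic acid or a longer chain, could bring the number clearly lower than the values seen so far.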